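Diethylamino on compound 3: what the earlier step suggests

This account rests on a few compounds, and the source may have more. Where it says the series, first, only, none or still open, it means among the compounds named here.

Values in a functional assay on WI-38 cells (Homo sapiens) for antiproliferative activity, read by MTT assay, with a stated time of 72 h; a higher number here means a weaker inhibitor, a lower number a stronger inhibitor:
compound 1 `NC(=S)N/N=C/c1ccccc1O`: >= 5000 nM
compound 2 `CCN(CC)c1ccc(/C=N/NC(N)=S)c(O)c1`: 200 nM
compound 3 `Oc1ccccc1/C=N/NC(=S)Nc1ccccc1`: 1300 nM

The entry for compound 1 is a limit of the assay and not a number. That leaves two true numbers. Compound 2 gives 200 nM and compound 3 gives 1300 nM, so compound 3 has the higher number and is the weaker inhibitor of this pair.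

The next compound is compound 4 `CCN(CC)c1ccc(/C=N/NC(=S)Nc2ccccc2)c(O)c1`, which differs from compound 3 in one place: diethylamino in place of hydrogen on an aromatic carbon. It keeps the phenyl group of compound 3 and gains diethylamino in place of hydrogen on an aromatic carbon.

Among the measured compounds shown here, two measured steps bear on this. The same swap has been seen once, as an at least 25-fold lower number from compound 1 to compound 2 (1.39 log units; beyond the scatter). Compound 3 itself arose by another change, an at least 3.8-fold lower number from compound 1 to compound 3 (0.58 log units; beyond the scatter). On these data alone, both steps start from a limit (the limit of >= 5000 nM in this assay, at which 1 of the 3 values shown sits), so their full sizes are unknown. Whether the two changes add up has not been tested, and one earlier example is thin support.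

A large step towards a lower number is still expected in this assay. The estimated step is a 13-fold lower number from compound 3 to compound 4 (1.11 log units; beyond the scatter). For compound 4 the expected value is 100 nM, with an estimated range from 25 nM to 450 nM.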

Compound 4, half-maximal inhibitory concentration: 300 nM
Estimate against measurement, compound 4: 3.0-fold (0.48 log units) below; measured number inside the range.
By their numbers in this assay, from the lowest: compounds 2 and 4 (each within the scatter of the next); then compound 3. At a limit, above all of these: compound 1.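

The diethylamino step also holds on the phenyl-bearing core, where this group stands para to a large group and meta to a hydroxy group: in this assay, the change gives a 4.3-fold lower number from compound 3 to compound 4 (0.64 log units; beyond the scatter). Its size, however, depends on the core that carries it, so the earlier step cannot simply be carried over from one core to the other: the same change on two cores in this assay, an at least 25-fold lower number (1.39 log units; beyond the scatter) from compound 1 to compound 2 and a 4.3-fold lower number (0.64 log units; beyond the scatter) from compound 3 to compound 4, at least 5.7-fold (0.76 log units) apart, beyond the scatter of two such steps. The phenyl group on the amide-type nitrogen behaves in the same way, since with diethylamino present the result is a 1.5-fold higher number from compound 2 to compound 4 (0.18 log units; within the scatter), which leaves compound 2 and compound 4 indistinguishable in this assay, although phenyl gave a clear step on the core of compound 1: the same change on two cores in this assay, an at least 3.8-fold lower number (0.58 log units; beyond the scatter) from compound 1 to compound 3 and a 1.5-fold higher number (0.18 log units; within the scatter) from compound 2 to compound 4, at least 5.7-fold (0.76 log units) apart, beyond the scatter of two such steps.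

On these data alone, compound 1 stands at a limit, so the full size of both steps that start from it, and of the gaps between steps, remains unknown: the limit of >= 5000 nM in this assay, at which 1 of the 4 values shown sits. As far as these compounds go, it also remains open whether dimethylamino or a cyclic amine such as pyrrolidine on the same aromatic carbon would give a similar step, and whether a longer alkyl chain in place of phenyl on the amide-type nitrogen would behave as phenyl does.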